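Removing One Methoxy Group in a Cytotoxicity Series

The source may report more compounds than this note shows. Statements on the series, on what has been measured and on what is new or still open speak of the compounds shown alone.

Compound 1 `COc1cc(-c2cc(/C=C/C(=O)c3ccc(N)cc3)[nH]n2)cc(OC)c1OC` was tested in a functional assay on OVCAR-3 cells (Homo sapiens) for cytotoxicity, read by sulforhodamine B assay, with a stated time of 48 h, tested at 100 uM (a lower number here means a stronger effect, a higher number a weaker effect of the compound at the concentration tested), where compound 1 gives -93%. Compound 2 `COc1ccc(-c2cc(/C=C/C(=O)c3ccc(N)cc3)[nH]n2)cc1OC` carries the change (hydrogen in place of methoxy on an aromatic carbon), and this step gave a number 6 percentage points lower from compound 1 to compound 2 (within the scatter). Compound 3 `COc1cc(C(=O)/C=C/c2cc(-c3cc(OC)c(OC)c(OC)c3)n[nH]2)cc(OC)c1OC` rests on a different core; the difference between the two cores is not broken down here. In this assay compound 3 gives -98%, while compound 2 gives -99%. Among the compounds with values here, compound 4 `COc1ccc(-c2cc(/C=C/C(=O)c3cc(OC)c(OC)c(OC)c3)[nH]n2)cc1OC` has not yet been measured; it differs from compound 3 by hydrogen in place of methoxy on an aromatic carbon, the same change as the one separating compound 1 and compound 2. Because the earlier step of a number 6 percentage points lower from compound 1 to compound 2 (within the scatter) stayed within the scatter, only a small shift is expected, namely a number 1 percentage points lower from compound 3 to compound 4 (within the scatter). Compound 4 is therefore estimated to give -99% in this assay, with a range from -106% to -88%.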

Compound 4, a percentage reported as activity, at one concentration (the size of the read-out at that concentration, not a potency): -83%
Beside the measured number, compound 4's estimate is 16 percentage points below it, and the stated range ends below it.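

Replacing methoxy with hydrogen in this assay gave a number 15 percentage points higher from compound 3 to compound 4 (beyond the scatter), so compound 4 shows the weaker effect of this pair at the concentration tested. The same change therefore did not carry over unchanged from one core to the other: the same change on two cores in this assay, a number 6 percentage points lower (within the scatter) from compound 1 to compound 2 and a number 15 percentage points higher (beyond the scatter) from compound 3 to compound 4, 21 percentage points apart, beyond the scatter of two such steps This shows that the outcome of the change differed between these two pairs, but it does not show what in the cores sets that difference, and it says nothing about any further core.

On these data alone, whether a hydroxy or an ethoxy group at the same place would track hydrogen or methoxy on either core remains open. A reading at one concentration also leaves open whether the stronger or weaker effect seen there would hold at any other concentration.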